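A few compounds are considered here, and "the series" means these few. Any claim that something is new, unique, unknown or untested is made for them only; others in the source may bear on it.

Compound 1 `O=C(CCCCC1CCSS1)NCc1cn(CCCCOc2ccc3ccc(=O)oc3c2)nn1` gives 40.5% in a functional assay on PC-12 cells (Rattus norvegicus) for cytotoxicity, read by MTT assay, with stated times of 3 h and 2 h, tested at 0.1 uM; a lower number here means a weaker effect, a higher number a stronger effect of the compound at the concentration tested.
Compound 2 `O=C(CCCCC1CCSS1)NCc1cn(CCCCOc2ccc3cc(-c4ccccc4)c(=O)oc3c2)nn1` gives 38.6% in this assay.

Going by the values given here, compound 2 stands at the lowest of the two numbers in this assay, and its nearest neighbour is compound 1, whose number lies within the scatter; the single measured step, phenyl in place of hydrogen on an aromatic carbon, reads a number 1.9 percentage points lower from compound 1 to compound 2 (within the scatter) and is within the scatter.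

Compound 3 `COc1ccc(-c2cc3ccc(OCCCCn4cc(CNC(=O)CCCCC5CCSS5)nn4)cc3oc2=O)cc1` differs from compound 2 by methoxy in place of hydrogen on an aromatic carbon.

Among the compounds with values here, only this one step bears on the new change, and only loosely, since it added a phenyl rather than a methoxy; it was small. Compound 3 is therefore expected to show no step beyond the scatter, a number 0.6 percentage points lower from compound 2 to compound 3 (within the scatter). The estimate for compound 3 in this assay is 38%, with a range from 30% to 46%.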

Compound 3, a percentage reported as activity, at one concentration (the size of the read-out at that concentration, not a potency): 32.1%
Estimate against measurement, compound 3: 5.9 percentage points above; the measured number falls inside the stated range.
By their numbers in this assay, from the lowest: compounds 3, 2 and 1 (each within the scatter of the next).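

Methoxy on an aromatic carbon, para to a large group, turns phenyl into 4-methoxyphenyl and gives a number 6.5 percentage points lower from compound 2 to compound 3 (within the scatter) in this assay, so this position carries a substituent on the added phenyl without a step beyond the scatter. The whole 4-methoxyphenyl in place of hydrogen gives a number 8.4 percentage points lower from compound 1 to compound 3 (within the scatter), so this larger change also stays within the scatter, and the read-out does not separate the three compounds. No available evidence accounts for these small steps.

The compounds shown leave open whether an amine, a carboxylic acid or a longer chain in place of the methoxy would give a step beyond the scatter. They also leave open whether methoxy at another place on the phenyl would read any differently from the 4-methoxyphenyl of compound 3.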